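A few compounds are considered here, and "the series" means these few. Any claim that something is new, unique, unknown or untested is made for them only; others in the source may bear on it.

Working notes on the solubility series. Compound 1 `[O-][n+]1nc(NCCN2CCCCC2)[n+]([O-])c2ccccc21` is reported in a physicochemical assay for solubility, in the presence of a further agent that is not named here (a lower number here means a less soluble compound, a higher number a more soluble compound), only as a limit of the assay, > 49000000 nM. Compound 2 `CC1CCCC(C)N1CCNc1n[n+]([O-])c2ccccc2[n+]1[O-]` gives 48000000 nM in this assay. Compound 3 `CCN(CC)CCNc1n[n+]([O-])c2ccc(Cl)cc2[n+]1[O-]` holds the lower of the two numbers, with 23000000 nM in this assay; its nearest neighbour, compound 2, sits a step higher that is beyond the scatter. Compound 4 `[O-][n+]1nc(NCCN2CCCCC2)[n+]([O-])c2cc(Cl)ccc21` is not yet measured. It differs from compound 3 by piperidin-1-yl in place of diethylamino on a saturated chain carbon, two bonds along the chain from a nitrogen on an aromatic ring. Among the compounds with values here, no measured pair isolates this exchange, and compounds 1 and 2 differ from compound 3 in more than one place. The step of a 1.1-fold higher number from compound 3 to compound 4 (0.04 log units; within the scatter) is expected to be small, within the scatter, in no settled direction. Compound 4 is estimated at 25000000 nM, with a range of 10000000 nM to 50000000 nM.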

Compound 4, solubility: 3200000 nM
Beside the measured number, compound 4's estimate is 7.8-fold (0.89 log units) above it; the whole stated range lies above it.
By their numbers in this assay, from the lowest: compound 4; then compound 3; then compound 2. At a limit, above all of these: compound 1.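

In this assay, within the data shown here, piperidin-1-yl in place of diethylamino on a saturated chain carbon, two bonds along the chain from a nitrogen on an aromatic ring, gives a 7.2-fold lower number from compound 3 to compound 4 (0.86 log units; beyond the scatter), the first measured pair to isolate this exchange. With piperidin-1-yl held constant, chloro in place of hydrogen on an aromatic carbon gives an at least 15-fold lower number from compound 1 to compound 4 (1.18 log units; beyond the scatter). Compound 1 stands at a limit, so this step has a minimum size only: the limit of > 49000000 nM in this assay, at which 1 of the 4 values shown sits.

Going by these compounds, whether the exchange gives a similar step without chloro remains open. Also open, on these data alone, is where a morpholine or a longer chain would fall.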